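Dropping a Fluoro Group from a Weak Inhibitor

The source may report more compounds than this note shows. Statements on the series, on what has been measured and on what is new or still open speak of the compounds shown alone.

Measured compounds:
compound 1 `Cc1ccc(CNC(=O)c2nn(-c3ccc(F)cc3)c(CC[C@@H](O)C[C@@H](O)CC(=O)O)c2C(C)C)cc1`, 730 nM
compound 2 `O=C(O)C[C@H](O)C[C@H](O)CCn1c(-c2ccc(F)cc2)nc(C(=O)NCc2ccccc2F)c1C1CC1`, 27200 nM

In a functional assay on L6 cells (Rattus norvegicus) for inhibition, read by scintillation counting, with a stated time of 3 h (on this read-out lower numbers stand for stronger inhibition and higher numbers for weaker inhibition), compound 1 gives 730 nM, while compound 2 gives 27200 nM, the higher of the two numbers and therefore the weaker inhibitor of the pair. Compound 3 `O=C(O)C[C@H](O)C[C@H](O)CCn1c(-c2ccc(F)cc2)nc(C(=O)NCc2ccccc2)c1C1CC1` differs from compound 2 by one small change: hydrogen in place of fluoro on an aromatic carbon. Among the measured compounds shown here, no measured pair shows this change, so the expectation rests on its small size alone. The step expected from compound 2 to compound 3 is a 1.1-fold lower number from compound 2 to compound 3 (0.04 log units; within the scatter), none beyond the scatter. Compound 3 is estimated at 25000 nM, within 9000 nM to 70000 nM.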

Compound 3, half-maximal inhibitory concentration: 632 nM
For compound 3 the middle estimate is 40-fold (1.60 log units) above the measured one; measured number outside the range, below it.
By their numbers in this assay, from the lowest: compounds 3 and 1 (each within the scatter of the next); then compound 2.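

Replacing 2-fluorobenzyl with benzyl gives, in this assay, a 43-fold lower number from compound 2 to compound 3 (1.63 log units; beyond the scatter), so on this core a single fluoro group, on an aromatic carbon ortho to a large group, can decide the reading. A change this small therefore cannot be assumed harmless at this position. No measurement at hand gives a reason for this step.

As far as these compounds go, it remains open whether a chloro or methoxy group in the same place would read like hydrogen or like fluoro. From the compounds shown here alone, the same swap on the core of compound 1 is also still open.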